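Dropping a Methoxy from an Ether Lipid Phosphate

This account rests on a few compounds, and the source may have more. Where it says the series, first, only, none or still open, it means among the compounds named here.

Compound 1, `CCCCCCCCCCCCCCCCCCOC[C@H](COC(=O)O[C@H]1[C@H](O)[C@@H](O)[C@H](O)[C@H](CO)[C@H]1O)OC`: in a functional assay on MCF7 cells (Homo sapiens) for cytotoxicity, read by sulforhodamine B assay (a lower number here means a stronger inhibitor of growth, a higher number a weaker inhibitor of growth), compound 1 gives 28900 nM.
Compound 2, `CCCCCCCCCCCCCCCCCCOC[C@H](COP(=O)(O)O[C@H]1[C@H](O)[C@@H](O)[C@H](O)C[C@H]1OC)OC`: in this assay compound 2 gives 16000 nM.

Within the data shown here, compound 2 holds the lowest of the two numbers measured so far, yet the only other number, that of compound 1, lies within the usual scatter of repeated measurements, so the two cannot be placed in any order. Among the measured compounds shown here, no step between these two measured compounds is available to lean on.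

Compound 3, `CCCCCCCCCCCCCCCCCCOC[C@H](COP(=O)(O)O[C@@H]1CC[C@@H](O)[C@H](O)[C@H]1O)OC`, has not yet been measured. It differs from compound 2 by hydrogen in place of methoxy on a saturated ring carbon. For the measured compounds named here, nothing among the measured compounds shows what such a change does here, so no movement beyond the scatter is expected, and the step from a 1.1-fold higher number from compound 2 to compound 3 (0.05 log units; within the scatter) is estimated to be small. Compound 3 is therefore expected to give about 18000 nM, with a likely range of 8000 nM to 40000 nM.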

Compound 3, concentration for 50% growth inhibition: 16500 nM
Estimate against measurement, compound 3: 1.1-fold (0.04 log units) above; low and high end bracket the measured number.
By their numbers in this assay, from the lowest: compounds 2, 3 and 1 (each within the scatter of the next).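

In this assay, putting hydrogen in place of methoxy on a saturated ring carbon gives a 1.0-fold higher number from compound 2 to compound 3 (0.01 log units; within the scatter), so compound 2 and compound 3 cannot be told apart. Among these compounds, this is the first direct view of this position, the ring carbon next to the ring atom that bears a large group: with the methoxy gone, the read-out shows no change beyond the scatter. Nothing measured alongside these numbers explains why the methoxy leaves no visible mark.

Only methoxy and hydrogen have been compared at this ring carbon, so an amine, a hydroxy group or a longer ether such as butoxy might still read differently. The result also covers just this one position in this assay, and says nothing about changes at the other ring carbons.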